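The compounds below may be only part of what the source reports. "The series", "measured", "known", "first", "only" and "open" are said of these compounds alone.

Measured compounds and their values:
compound 1 `CC(C(=O)N1CCN(c2ccccc2)CC1)N1C(=O)CCC1=O` gives 0%
compound 2 `CC(C(=O)N1CCN(c2ccc(Cl)cc2)CC1)N1C(=O)CCC1=O` gives 0%

Both were run in a functional assay on the whole organism (strain Swiss) with Mus musculus as the target, in the maximal electroshock model, with a stated time of 2 h, at a dose of 300 mg/kg by the intraperitoneal route; on this read-out lower numbers stand for a weaker effect and higher numbers for a stronger effect at the one dose given. The one measured step in the set, no change at the digits printed from compound 1 to compound 2 (within the scatter), was a chloro in place of hydrogen on an aromatic carbon, and it moved nothing at the digits shown. Compound 2 therefore stands level with compound 1; neither shows any effect in this assay at the dose used, and no word of order between the two is warranted.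

Compound 3 `CC(C(=O)N1CCN(c2ccc(C(F)(F)F)cc2)CC1)N1C(=O)CCC1=O` is the next member. It differs from compound 2 by trifluoromethyl in place of chloro on an aromatic carbon.

Going by the values given here, the only step that bears on this change is the one from compound 1 to compound 2, a substitution at the same aromatic carbon, and it was flat. Among the compounds with values here, no measured step involves a trifluoromethyl anywhere, so there is nothing to point to a gain or a loss. The expected step of no change at the digits printed from compound 2 to compound 3 (within the scatter) is none beyond the scatter, because the earlier change at that carbon gave no change at the digits printed from compound 1 to compound 2 (within the scatter). Compound 3 is therefore expected to give 0% in this assay, within a range from 0% to 20%.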

Compound 3, a percentage reported as activity, at one dose (the size of the read-out at that dose, not a potency): 0%
Beside the measured number, compound 3's estimate shows no gap at the digits printed; the measured number falls inside the stated range.
By their numbers in this assay, from the lowest: compounds 1, 2 and 3 (each within the scatter of the next).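

In this assay, at this aromatic carbon, para to a large group, trifluoromethyl in place of chloro brings four heavy atoms in for one and gives no change at the digits printed from compound 2 to compound 3 (within the scatter) at the one dose used. Trifluoromethyl in place of hydrogen on the same carbon gives no change at the digits printed from compound 1 to compound 3 (within the scatter) and so adds a second substituent to chloro that leaves the read-out level with the unsubstituted compound 1, where the earlier compounds offered only one such comparison. No measurement is available that speaks to the reason for this flat result.

With all three compounds showing no effect, this set gives no active reference against which a substituent at this carbon could register as a gain or a loss, and it says nothing about effects at other doses or times. Going by these compounds, whether an amine or a carboxylic acid on this aromatic carbon, a longer chain in place of the methyl, or another change to the shared core would produce any effect in this assay remains open.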